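Trifluoromethoxy in Place of Fluoro: Expectation for Compound 3

The compounds below may be only part of what the source reports. "The series", "measured", "known", "first", "only" and "open" are said of these compounds alone.

Compound 2 `Oc1cc(C(F)(F)F)ccc1-c1nc(-c2ccccc2O)n(-c2ccc(F)cc2)n1` stands as the lower of two numbers in a functional assay on PC-12 cells (Rattus norvegicus) for cytotoxicity, read by MTT assay, with stated times of 2 h and 24 h, tested at 10 uM (on this read-out lower numbers stand for a weaker effect and higher numbers for a stronger effect at the one concentration tested), where compound 2 gives 99.8%, while compound 1 `CCc1ccc(-n2nc(-c3ccc(C(F)(F)F)cc3O)nc2-c2ccccc2O)cc1` gives 107%; the step of a number 7.2 percentage points lower from compound 1 to compound 2 (within the scatter) lies within the scatter. Compound 3 `Oc1cc(C(F)(F)F)ccc1-c1nc(-c2ccccc2O)n(-c2ccc(OC(F)(F)F)cc2)n1` differs from compound 2 by trifluoromethoxy in place of fluoro on an aromatic carbon. Within the data shown here, the only measured step at this position, a number 7.2 percentage points lower from compound 1 to compound 2 (within the scatter), moved the read-out by nothing beyond the scatter, so a further exchange there is expected to shift this assay little in either direction. Compound 3 is therefore estimated at 100%, between 85% and 115%, an expected step of a number 0.2 percentage points higher from compound 2 to compound 3 (within the scatter) that stays within the scatter.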

Compound 3, a percentage reported as activity, at one concentration (the size of the read-out at that concentration, not a potency): 92.5%
Beside the measured number, compound 3's estimate is 7.5 percentage points above it, within the range that was stated.
By their numbers in this assay, from the lowest: compounds 3, 2 and 1 (each within the scatter of the next, the first and the last beyond it).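

In this assay this position now shows its first difference beyond the scatter, a modest one: a number 14.5 percentage points lower from compound 1 to compound 3 (beyond the scatter), for trifluoromethoxy in place of ethyl. The exchange of fluoro for trifluoromethoxy stays within the scatter, a number 7.3 percentage points lower from compound 2 to compound 3 (within the scatter), so compound 2 cannot be told apart from either compound 1 or compound 3. No evidence at hand accounts for the gap between ethyl and trifluoromethoxy. Going by these compounds, what an amine or a carboxylic acid on this aromatic carbon would do to the read-out stays open, and so does whether this single gap would persist at another concentration.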